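The source may report more compounds than this note shows. Statements on the series, on what has been measured and on what is new or still open speak of the compounds shown alone.

Working notes on the series. Compound 1 `O=C1C(Nc2ccc(-c3ccccc3)cc2)=CC(=O)c2ncncc21` is the reference point: in a functional assay on PANC-1 cells (Homo sapiens) for cytotoxicity, read by MTT assay, with a stated time of 72 h (a higher number here means a weaker inhibitor, a lower number a stronger inhibitor), compound 1 gives 400 nM, the lowest of the three numbers in hand. Compound 2 `O=C1C(NCc2ccc(F)cc2)=CC(=O)c2ncncc21` gives 1000 nM in this assay, and compound 3 `COc1ccc(-c2ccc(NC3=CC(=O)c4ncncc4C3=O)cc2)cc1` gives 2300 nM in this assay, so both sit higher than compound 1 by more than the scatter. Among the measured compounds shown here, the one single-point step measured so far runs outward from compound 1: a 5.8-fold higher number from compound 1 to compound 3 (0.76 log units; beyond the scatter).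

Compound 4 `CCOC(=O)c1ccc(NC2=CC(=O)c3ncncc3C2=O)cc1` is next to be tested. It differs from compound 1 by ethoxycarbonyl in place of phenyl on an aromatic carbon. For the measured compounds named here, no measured pair covers this exchange directly; the step from compound 1 to compound 3 is the only one touching the same distal region, and it went modestly toward a higher number. On that slender basis a weakening of similar size is expected in this assay rather than a gain, though the uncertainty is wide. The step from compound 1 to compound 4 is therefore estimated as a 3.8-fold higher number from compound 1 to compound 4 (0.57 log units; beyond the scatter). For compound 4 the expected value in this assay is 1500 nM, with a range from 500 nM to 5000 nM.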

Compound 4, half-maximal inhibitory concentration: 1600 nM
Compound 4: the middle estimate sits 1.1-fold (0.03 log units) below what was measured, and the stated range covers the measured number.
By their numbers in this assay, from the lowest: compound 1; then compounds 2, 4 and 3 (each within the scatter of the next, the first and the last beyond it).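

In this assay the exchange of phenyl for ethoxycarbonyl gives a 4.0-fold higher number from compound 1 to compound 4 (0.60 log units; beyond the scatter), so a second group at this place, para to a large group, also stands above the phenyl of compound 1, this time a group with no ring and with hydrogen-bond acceptors. The further reading is a 1.4-fold lower number from compound 3 to compound 4 (0.16 log units; within the scatter), which means that ethoxycarbonyl and 4-methoxyphenyl cannot be told apart here, although only one of them carries a ring. No measurement in hand explains either step.

Open, as far as these compounds go, is whether a carboxylic acid, an amide or a primary amine at this place would stay with ethoxycarbonyl or come back toward phenyl. Also open, from the compounds shown here alone, is how a longer ester chain or a phenyl carrying fluorine would read in this assay.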